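Amide to carbamoyl change at the carbonyl of the shared core

The source may report more compounds than this note shows. Statements on the series, on what has been measured and on what is new or still open speak of the compounds shown alone.

Values in a functional assay on HCT-116 cells (Homo sapiens) for antiproliferative activity, read by MTT assay, with a stated time of 72 h (on this read-out lower numbers stand for stronger inhibition and higher numbers for weaker inhibition), so far:
compound 1 `CN(C(=O)c1ccc(F)cc1)c1ccc2[nH]c(-c3n[nH]c4ccccc34)cc2n1`: 9270 nM
compound 2 `CN(C(=O)c1ccc(Br)cc1)c1ccc2[nH]c(-c3n[nH]c4ccccc34)cc2n1`: 6110 nM
compound 3 `CN(C(=O)c1ccccc1)c1ccc2[nH]c(-c3n[nH]c4cc(C#N)ccc34)cc2n1`: 24000 nM

Compound 2 gives the lowest of the three numbers, but the gap is a 1.5-fold lower number from compound 1 to compound 2 (0.18 log units; within the scatter), so no order between compound 1 and compound 2 can be read; only compound 3 stands clearly apart from compound 2.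

Compound 4 `CN(C(=O)Nc1ccccc1)c1ccc2[nH]c(-c3n[nH]c4ccccc34)cc2n1` has not been measured. It differs from compound 2 by anilino in place of 4-bromophenyl on a carbonyl carbon. Among the measured compounds shown here, the one measured single-change step, a 1.5-fold lower number from compound 1 to compound 2 (0.18 log units; within the scatter), concerns a group on the aromatic ring and not the carbonyl substituent, so it does not bear on this change. For the measured compounds named here, compound 3 differs from compound 1 and compound 2 in two places and yields no single-change step. Nothing measured here addresses replacing the carbonyl-borne ring, so no step beyond the scatter is expected, and the range is kept wide. Compound 4 is expected at 8000 nM in this assay, between 2500 nM and 25000 nM. This estimate corresponds to an expected step of a 1.3-fold higher number from compound 2 to compound 4 (0.12 log units; within the scatter).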

Compound 4, half-maximal inhibitory concentration: 1.3 nM
For compound 4 the middle estimate is 6200-fold (3.79 log units) above the measured one, and the stated range ends above it.
By their numbers in this assay, from the lowest: compound 4; then compounds 2 and 1 (each within the scatter of the next); then compound 3.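

In this assay, the group on the carbonyl carbon is where the series responds most strongly so far: anilino in place of 4-bromophenyl gives a 4700-fold lower number from compound 2 to compound 4 (3.67 log units; beyond the scatter), and anilino in place of 4-fluorophenyl gives a 7100-fold lower number from compound 1 to compound 4 (3.85 log units; beyond the scatter), whereas the halogen swap gave only a 1.5-fold lower number from compound 1 to compound 2 (0.18 log units; within the scatter). The aromatic carbon ring is present on both sides of the change, so a carbonyl-borne ring alone does not give this level of inhibition; the change that matters here is the step from (4-bromophenyl)carbonyl to phenylcarbamoyl. No data on hand explain the size of this step.

The compounds shown leave open whether the hydrogen on the anilino nitrogen is needed, a question that an N-methylanilino group would address. Also open, going by these compounds, is whether the aromatic ring itself is required, as a cyclohexylamino or benzylamino group on the carbonyl carbon would show.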